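The source may report more compounds than this note shows. Statements on the series, on what has been measured and on what is new or still open speak of the compounds shown alone.

Values in an ADME assay on Vero cells (Chlorocebus sabaeus) for cytotoxicity, read by neutral red uptake, with a stated time of 48 h; on this read-out higher numbers stand for weaker inhibition and lower numbers for stronger inhibition:
compound 1 `CN(C)c1nc(Cl)nc2c1ncn2CCCNc1ccnc2cc(Cl)ccc12`: > 11400 nM
compound 2 `Clc1ccc2c(NCCCn3cnc4c(N5CCCC5)nc(Cl)nc43)ccnc2c1`: > 10700 nM
compound 3 `Clc1ccc2c(NCCCn3cnc4c(N5CCCCCC5)nc(Cl)nc43)ccnc2c1`: > 10100 nM

Compound 3 gives > 10100 nM, which is a limit and not a number. Compound 1 and compound 2 also give only limits, so none of the three has a true half-maximal value in this assay.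

Compound 4 `CCN1CCN(c2nc(Cl)nc3c2ncn3CCCNc2ccnc3cc(Cl)ccc23)CC1` keeps the shared core and changes one group: 4-ethylpiperazin-1-yl in place of azepan-1-yl on an aromatic carbon. The same carbon carries the group that varies in the three measured steps: a step that the two limits leave unreadable from compound 1 to compound 2, a step that the two limits leave unreadable from compound 1 to compound 3 and a step that the two limits leave unreadable from compound 2 to compound 3. None of these has a readable size, yet dimethylamino, pyrrolidin-1-yl and azepan-1-yl all leave compound 1, compound 2 and compound 3 at limits. On that basis, no step beyond the usual scatter is expected, in either direction, and another limit is the likeliest report. The estimated step is an at least 1.0-fold lower number from compound 3 to compound 4 (0.01 log units; that floor lies within the scatter). For compound 4 the expected value is 9800 nM, with an estimated range from 4500 nM to 15000 nM.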

Compound 4, half-maximal inhibitory concentration: > 9830 nM
Compound 4 gave a limit, no number (the forecaster's own chance of this, stated with the estimate: 75%); middle value at least 1.0-fold (0.00 log units) away from the limit.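

Compound 4 also gives only a limit, so its steps from compound 1, compound 2 and compound 3 cannot be read in this assay. The compounds shown leave open whether changing the group on that aromatic carbon alters the true half-maximal value at all.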